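The source may hold more compounds than are shown below. What is called first, only, known or untested is meant among the compounds shown, and "the series" means these compounds.

Compound 1 `COc1ccc([C@@H]2c3c(OC)cc(OC)cc3/C(=C/c3ccccc3)[C@H]2c2cc(OC)cc(OC)c2)cc1`: > 200000 nM, which is a limit of the assay.
Compound 2 `COc1ccc([C@@H]2c3c(OC)cc(OC)cc3C(O)[C@H]2c2cc(OC)cc(OC)c2)cc1`: 7870 nM.
Compound 3 `COc1ccc(CSC2c3cc(OC)cc(OC)c3[C@@H](c3ccc(OC)cc3)[C@@H]2c2cc(OC)cc(OC)c2)cc1`: 12500 nM.

In a functional assay on RAW264.7 cells (Mus musculus) for inhibition, with stated times of 2 h and 24 h (a higher number here means a weaker inhibitor, a lower number a stronger inhibitor), compound 3 lies within the usual scatter of compound 2. Compound 4 `COc1ccc(CSC2c3cc(OC)cc(OC)c3[C@@H](c3ccccc3)[C@@H]2c2cc(OC)cc(OC)c2)cc1` differs from compound 3 by one change: hydrogen in place of methoxy on an aromatic carbon, para to a large group, which turns 4-methoxyphenyl into phenyl (hydrogen in place of methoxy on an aromatic carbon). Among the measured compounds shown here, no measured step involves this group. The only one available, a 1.6-fold higher number from compound 2 to compound 3 (0.20 log units; within the scatter), changes a different place, so it offers little guidance. No direction can be favoured, and no shift beyond the scatter is expected. The expected step is a 1.0-fold lower number from compound 3 to compound 4 (0.02 log units; within the scatter). Compound 4 is estimated at 12000 nM, with an expected range of 4000 nM to 35000 nM.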

Compound 4, half-maximal inhibitory concentration: > 200000 nM
Compound 4 was reported as a limit; the forecaster's own chance of this, stated with the estimate: 10%; middle value at least 16-fold (1.22 log units) from the limit.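

In this assay, replacing 4-methoxyphenyl with phenyl gives an at least 16-fold higher number from compound 3 to compound 4 (1.20 log units; beyond the scatter). The methoxy on this aromatic carbon, para to a large group, therefore makes a large difference, which the earlier step at another place could not reveal. The full size of the step stays unknown, since compound 4 sits at a limit of the assay: the limit of > 200000 nM in this assay, at which 2 of the 4 values shown sit.

On these data alone, whether a hydroxy, fluoro or ethoxy group here would keep the number close to that of compound 3 remains open. Also open, as far as these compounds go, is whether the same change has as large an effect when hydroxy replaces the (4-methoxybenzyl)sulfanyl group.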